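Swapping trifluoromethyl for chloro on the outer ring

A few compounds are considered here, and "the series" means these few. Any claim that something is new, unique, unknown or untested is made for them only; others in the source may bear on it.

Three compounds share one core and differ only in the group on the six-membered ring of carbon only. Compound 1 `C/C(=C\c1cc(-c2ccc(F)cc2)cs1)C(N)=O` carries fluoro there, compound 2 `C/C(=C\c1cc(-c2ccc(C#N)cc2)cs1)C(N)=O` cyano, and compound 3 `C/C(=C\c1cc(-c2ccc(C(F)(F)F)cc2)cs1)C(N)=O` trifluoromethyl. In a functional assay on HO8910 cells (Homo sapiens) for cytotoxicity, read by CCK-8 assay, with a stated time of 24 h (a higher number here means a weaker inhibitor, a lower number a stronger inhibitor), compound 2 gives 130 nM. Compound 1 reaches only the limit > 50000 nM. Compound 3 also sits at the limit > 50000 nM, in line with the limit of > 50000 nM in this assay, at which 2 of the 3 values shown sit. The step of an at least 380-fold higher number from compound 2 to compound 3 (2.58 log units; beyond the scatter) was large, while the step that the two limits leave unreadable from compound 1 to compound 3 cannot be read. Compound 4 `C/C(=C\c1cc(-c2ccc(Cl)cc2)cs1)C(N)=O` differs from compound 3 by chloro in place of trifluoromethyl on an aromatic carbon. Because the step of an at least 380-fold higher number from compound 2 to compound 3 (2.58 log units; beyond the scatter) showed that leaving cyano lost most activity, and compound 1 likewise sits at its limit, compound 4 is expected to stay weak. The expected step is an at least 1.2-fold lower number from compound 3 to compound 4 (0.09 log units; that floor lies within the scatter). Compound 4 is estimated at 40000 nM, between 5000 nM and 100000 nM.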

Compound 4, half-maximal inhibitory concentration: > 50000 nM
Compound 4: no number, only a limit (the forecaster's own chance of this, stated with the estimate: 70%); at least 1.2-fold (0.09 log units) between middle value and limit.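

Chloro is now a third group, after fluoro and trifluoromethyl, that gives no number in this assay, and cyano remains the only group here with a measured value. Putting chloro in place of cyano gives an at least 380-fold higher number from compound 2 to compound 4 (2.58 log units; beyond the scatter), while the steps from compound 1 and compound 3 to compound 4 cannot be read, each joining two limits. The result for compound 4 is itself a limit, as with most of this small set: the limit of > 50000 nM in this assay, at which 3 of the 4 values shown sit.

From the compounds shown here alone, whether cyano alone gives this activity stays open, as an amine or a carboxylic acid at this position could show. Going by these compounds, how far compound 1, compound 3 and compound 4 truly differ also remains unknown.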